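The compounds below may be only part of what the source reports. "The series", "measured", "known", "first", "only" and "open" are said of these compounds alone.

Of the compounds shown here, three built on one shared core have been measured so far. Compound 1 `CN(C)c1ccc2c(=O)c(C(=O)Nc3cc(F)cc(F)c3)cn(-c3ccc(OCCCCCCC[n+]4ccccc4)c(Cl)c3)c2n1` and compound 2 `CN(C)c1ccc2c(=O)c(C(=O)Nc3cc(F)cc(F)c3)cn(-c3ccc(Cl)c(OCCCCCCC[n+]4ccccc4)c3)c2n1` contain the same atoms joined in a different arrangement; the difference between the two cores is not broken down here. Compound 3 `CC[N+]1(CCCCCCCOc2ccc(-n3cc(C(=O)Nc4cc(F)cc(F)c4)c(=O)c4ccc(N(C)C)nc43)cc2Cl)CCCCC1` is compound 1 with one group exchanged, described as a group of 8 heavy atoms (7 carbon, 1 nitrogen; one six-membered non-aromatic ring with 1 hetero atom) in place of a group of 6 heavy atoms (5 carbon, 1 nitrogen; one six-membered aromatic ring with 1 hetero atom), on a saturated chain carbon, seven bonds along the chain from an oxygen on an aromatic ring.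

In an assay on LX2 cells for inhibition of COL1A1 promoter (Homo sapiens), read by a luciferase reporter, with a stated time of 24 h, tested at 50 uM (on this read-out lower numbers stand for a weaker effect and higher numbers for a stronger effect at the one concentration tested), compound 1 gives 21.4%. Compound 2 gives 77.9% in this assay, the highest of the three values, and compound 3 gives 50.4%. The exchange from compound 1 to compound 3 moved the read-out a number 29 percentage points higher from compound 1 to compound 3 (beyond the scatter).

Compound 4 `CC[N+]1(CCCCCCCOc2cc(-n3cc(C(=O)Nc4cc(F)cc(F)c4)c(=O)c4ccc(N(C)C)nc43)ccc2Cl)CCCCC1` has not yet been measured in this assay. It is related to compound 2 in the same way that compound 3 is related to compound 1: the change is a group of 8 heavy atoms (7 carbon, 1 nitrogen; one six-membered non-aromatic ring with 1 hetero atom) in place of a group of 6 heavy atoms (5 carbon, 1 nitrogen; one six-membered aromatic ring with 1 hetero atom), on a saturated chain carbon, seven bonds along the chain from an oxygen on an aromatic ring, at a place described in the same words in both pairs, so it is the same change made on the other core.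

Within the data shown here, the only guide for the step from compound 2 to compound 4 is the step from compound 1 to compound 3. Because compound 2 already stands at 77.9%, which leaves much less room before the read-out reaches its full extent, the step is estimated as a number 7.1 percentage points higher from compound 2 to compound 4 (within the scatter), smaller than the earlier one. On that basis the read-out of compound 4 in this assay is expected to be 85%, somewhere between 62% and 98%.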

Compound 4, a percentage reported as inhibition, at one concentration (the size of the read-out at that concentration, not a potency): "not active" (no number reported)
Compound 4 has no reported number here; no gap can be computed for the estimate.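

In this assay, among these compounds, compound 4 is reported only as not active, with no number, so no step from compound 2 to compound 4 can be read. Nothing available here offers an explanation for this result. The compounds shown leave open how large the change from compound 2 to compound 4 is, and whether the same exchange of groups acts alike on the two cores.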